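This account rests on a few compounds, and the source may have more. Where it says the series, first, only, none or still open, it means among the compounds named here.

Compound 1 `COc1cc(C[C@@H]2C(=O)OC[C@H]2[C@@H](O[C@@H]2O[C@H](CO)[C@@H](O)[C@H](O)[C@H]2O)c2ccc(O)c(OC)c2)ccc1O`: > 10000 nM
Compound 2 `COc1cc(C[C@@H]2C(=O)OC[C@H]2[C@@H](O)c2ccc(O[C@@H]3O[C@H](CO)[C@@H](O)[C@H](O)[C@H]3O)c(OC)c2)ccc1O`: > 10000 nM

Both of the values shown are limits of a functional assay on A549 cells (Homo sapiens) for cytotoxicity, read by sulforhodamine B assay, with a stated time of 48 h (on this read-out higher numbers stand for weaker inhibition and lower numbers for stronger inhibition), rather than numbers. Compound 1 gives > 10000 nM, which is a limit. Compound 2 gives > 10000 nM, likewise a limit. Neither compound reached a half-maximal inhibitory concentration that the assay could report. Compound 2 therefore stands at the edge of what this assay can resolve, and compound 1 stands at that same edge, as the limit of > 10000 nM in this assay, at which 2 of the 2 values shown sit, makes clear. Going by the values given here, no step between two measured compounds is available to gauge how a structural change moves the read-out.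

Compound 3 `COc1cc(C[C@@H]2C(=O)OC[C@H]2[C@@H](O)c2cc(OC)c(O[C@@H]3O[C@H](CO)[C@@H](O)[C@H](O)[C@H]3O)c(OC)c2)ccc1O` differs from compound 2 by methoxy in place of hydrogen on an aromatic carbon. With both measured compounds sitting at the limit (the limit of > 10000 nM in this assay, at which 2 of the 2 values shown sit), the step that the limit leaves unreadable from compound 2 to compound 3 is expected to be none beyond the scatter. Compound 3 is expected to give 20000 nM, within a range from 8000 nM to 60000 nM, and most probably the assay will again report only a limit for compound 3 rather than a number.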

Compound 3, half-maximal inhibitory concentration: > 10000 nM
Compound 3 ended at the assay's limit (the forecaster's own chance of this, stated with the estimate: 85%); the middle value is on the limit's open side.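

Compound 2 and compound 3 both stand at a limit rather than a number in this assay, so the step between them cannot be read: the limit of > 10000 nM in this assay, at which 3 of the 3 values shown sit.

The compounds shown leave open whether methoxy in place of hydrogen on an aromatic carbon changes the read-out at all, and how far each compound lies beyond the limit.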